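Hydroxy to azido on the fused core: an expectation

The compounds below may be only part of what the source reports. "The series", "measured", "known", "first", "only" and "open" are said of these compounds alone.

Measured compounds:
compound 1 `O=C(/C=C/c1c[nH]c2ccc(O)cc12)c1ccncc1` — 72%
compound 2 `Cc1[nH]c2ccc(O)cc2c1/C=C/C(=O)c1ccncc1` — 43%

In a functional assay on U-251 cells (Homo sapiens) for inhibition, read by colony formation, with stated times of 48 h and 2 weeks, tested at 10 uM (on this read-out higher numbers stand for more inhibition at the one concentration tested (going by the name of the read-out) and lower numbers for less inhibition), compound 1 gives 72% and compound 2 gives 43%. Going by the values given here, compound 2 therefore stands lowest of the two numbers known so far; its nearest neighbour is compound 1, and the single measured step, a number 29 percentage points lower from compound 1 to compound 2 (beyond the scatter), separates them by more than the usual scatter.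

Compound 3 `Cc1[nH]c2ccc(N=[N+]=[N-])cc2c1/C=C/C(=O)c1ccncc1` is the next compound in this series. It differs from compound 2 in one place: azido in place of hydroxy on an aromatic carbon.

Among the compounds with values here, the only measured step in this assay concerns a methyl in place of hydrogen on an aromatic carbon, a different group at a different place, so it does not bear on an azido in place of hydroxy. Within the data shown here, no measured step speaks to this change, and there is no second pair for comparison. With nothing to point either way, the expectation for compound 3 is a step that stays within the scatter, no change at the digits printed from compound 2 to compound 3 (within the scatter), with the range widened to allow for the unknown. Compound 3 is thus estimated at 43%, between 20% and 66%.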

Compound 3, a percentage reported as inhibition, at one concentration (the size of the read-out at that concentration, not a potency): "active" (no number reported)
Compound 3 has no reported number here; there is nothing to compare the estimate with.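

In this assay, going by these compounds alone, compound 3 is recorded only as active, without a number, so no step from compound 2 to compound 3 can be read. No evidence is available that bears on this result. The compounds shown leave open how far azido in place of hydroxy shifts inhibition from the level of compound 2 at 43% on this read-out.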